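Swapping a dichlorophenyl for a vinylphenyl on the core

A few compounds are considered here, and "the series" means these few. Any claim that something is new, unique, unknown or untested is made for them only; others in the source may bear on it.

Of the compounds shown here, three that share one core have been measured in a functional assay (muscle tissue) with Cavia porcellus as the target; on this read-out higher numbers stand for an effect only at larger amounts of compound and lower numbers for an effect already at smaller amounts. Compound 1 `COC(=O)C1=C(C)N=C(C)/C(=C(\O)OC)C1c1cc(Cl)cc(Cl)c1` gives 93.3 nM. Compound 2 `COC(=O)C1=C(C)N=C(C)/C(=C(\O)OC)C1c1ccccc1I` gives 46.8 nM, and compound 3 `COC(=O)C1=C(C)N=C(C)/C(=C(\O)OC)C1c1ccccc1OC` gives 57.5 nM. Compound 1 holds the highest of the three numbers, but both of its steps fall inside the usual scatter: a 2.0-fold lower number from compound 1 to compound 2 (0.30 log units; within the scatter) and a 1.6-fold lower number from compound 1 to compound 3 (0.21 log units; within the scatter). The two ortho-substituted analogues also sit close to each other, with a 1.2-fold higher number from compound 2 to compound 3 (0.09 log units; within the scatter).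

Compound 4 `C=Cc1ccccc1C1C(C(=O)OC)=C(C)N=C(C)/C1=C(\O)OC` has not yet been measured. It differs from compound 1 as follows: 2-vinylphenyl in place of 3,5-dichlorophenyl on a saturated ring carbon. The change therefore follows the same pattern as the two measured steps from compound 1, where a 3,5-dichlorophenyl gave way to a phenyl carrying a single group at the 2-position. Both of those steps moved the number down, yet neither left the scatter, so the account expects no more than a small drift for compound 4 as well, if anything toward a lower number, with the step from compound 1 estimated as a 1.6-fold lower number from compound 1 to compound 4 (0.19 log units; within the scatter). Accordingly, compound 4 is expected to reach about 60 nM in this assay, within a range from 25 nM to 150 nM.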

Compound 4, half-maximal effective concentration: 4.47 nM
Beside the measured number, compound 4's estimate is 13-fold (1.13 log units) above it; the whole stated range lies above it.
By their numbers in this assay, from the lowest: compound 4; then compounds 2, 3 and 1 (each within the scatter of the next).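

In this assay, for the compounds shown here, the group on this saturated ring carbon matters far more than the earlier compounds could show: their numbers all lay within the scatter of one another, whereas 2-vinylphenyl in place of 3,5-dichlorophenyl gives a 21-fold lower number from compound 1 to compound 4 (1.32 log units; beyond the scatter) and so opens the first large gap in the set. A single group on that aromatic carbon is not enough to produce this gap, for vinyl in place of methoxy gives a 13-fold lower number from compound 3 to compound 4 (1.11 log units; beyond the scatter) and vinyl in place of iodo gives a 10-fold lower number from compound 2 to compound 4 (1.02 log units; beyond the scatter), even though the methoxy and iodo analogues stand within the scatter of each other. Among these four compounds the low number therefore goes with the vinyl group alone, and nothing available here says why it separates from the others.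

From the compounds shown here alone, it remains open whether the double bond outside the aromatic ring is what counts, or whether an ethyl, an ethynyl or an allyl group on the same aromatic carbon would give a similar number. Also open, going by these compounds, is how vinyl would fare elsewhere on the phenyl ring, or alongside a chlorine on it.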